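The compounds below may be only part of what the source reports. "The series", "measured", "known", "first", "only" and "open" are said of these compounds alone.

Working notes on a small set of nucleoside-type compounds tested in a functional assay (Homo sapiens) for inhibition of Nucleic Acid, tested at 100 uM; a lower number here means less inhibition, a higher number more inhibition at the concentration tested (going by the name of the read-out). Compound 1 `CN(C)c1nccc2c1ncn2[C@H]1C[C@H](O)[C@@H](CO)O1` gives 0% in this assay, the lowest of the three numbers recorded so far. Compound 2 `[O-][n+]1ccc2c(c1)ncn2C1O[C@H](CO)[C@@H](O)[C@H]1O` gives 5%, a number that lies within the scatter of compound 1, so no order between the two can be drawn. Among the compounds with values here, compound 3 `C[C@H]1OC(n2cnc3c(N)nccc32)[C@H](O)[C@@H]1O` gives 18%, the only number that stands beyond the scatter of compound 1. Within the data shown here, no pair of measured compounds differs in a single place, so the effect of any one change has not been isolated in this set.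

Compound 4 `OC[C@H]1O[C@@H](n2cnc3c(S)nccc32)C[C@@H]1O` has not yet been tested in this assay. Relative to compound 1 it differs as follows: sulfanyl in place of dimethylamino on an aromatic carbon. Among the measured compounds shown here, with no measured single-place step to lean on, the expected step of a number 8 percentage points higher from compound 1 to compound 4 (within the scatter) is small and most likely not beyond the scatter, with any movement more likely upward than downward. Compound 4 is accordingly estimated at 8% in this assay, within a range from 0% to 25%.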

Compound 4, a percentage reported as inhibition, at one concentration (the size of the read-out at that concentration, not a potency): 10%
Estimate against measurement, compound 4: 2 percentage points below; the range from low to high includes it.
By their numbers in this assay, from the lowest: compounds 1, 2, 4 and 3 (each within the scatter of the next, the first and the last beyond it).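

Within the data shown here, the exchange of dimethylamino for sulfanyl on an aromatic carbon, next to the ring nitrogen, gives the first single-place step: a number 10 percentage points higher from compound 1 to compound 4 (within the scatter) in this assay on the core of compound 1. At this position, then, replacing a group of 3 heavy atoms with 0 hydrogen-bond donors by a group of 1 heavy atom with 1 hydrogen-bond donor does not carry the number past the usual scatter. No independent measurement bears on this step, so nothing can be said about what lies behind it.

From the compounds shown here alone, whether an amine, a methoxy group or a longer alkyl chain on the same aromatic carbon would move the number beyond the scatter remains open. A single step also leaves open whether the same exchange would behave alike on a different sugar portion.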